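Urea-hydrazone quinazolines: a diethylamino swap on a methoxy core

The source may report more compounds than this note shows. Statements on the series, on what has been measured and on what is new or still open speak of the compounds shown alone.

Measured so far:
compound 1, `O=C(N/N=C/c1ccc(O)cc1O)Nc1cc2c(Nc3ccc(F)c(Cl)c3)ncnc2cc1O[C@H]1CCOC1`: 7540 nM
compound 2, `CCN(CC)c1ccc(/C=N/NC(=O)Nc2cc3c(Nc4ccc(F)c(Cl)c4)ncnc3cc2O[C@H]2CCOC2)c(O)c1`: 4590 nM
compound 3, `COc1cc2ncnc(Nc3ccc(F)c(Cl)c3)c2cc1NC(=O)N/N=C/c1ccc(O)cc1O`: 29500 nM

Of the compounds shown here, three have been measured in a functional assay on PC-3 cells (Homo sapiens) for cytotoxicity, read by MTT assay, with a stated time of 72 h; on this read-out higher numbers stand for weaker inhibition and lower numbers for stronger inhibition. Compound 1 gives 7540 nM. Compound 2 carries the change diethylamino in place of hydroxy on an aromatic carbon and gives 4590 nM, so that a 1.6-fold lower number from compound 1 to compound 2 (0.22 log units; within the scatter). Compound 3 differs from compound 1 in its core, (methyl in place of oxolan-3-yl on an oxygen on an aromatic ring), and compound 3 gives 29500 nM; here a 3.9-fold higher number from compound 1 to compound 3 (0.59 log units; beyond the scatter), and compound 3 stands as the highest of the three numbers.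

Compound 4, `CCN(CC)c1ccc(/C=N/NC(=O)Nc2cc3c(Nc4ccc(F)c(Cl)c4)ncnc3cc2OC)c(O)c1`, has not yet been measured in this assay. It differs from compound 3 by diethylamino in place of hydroxy on an aromatic carbon, the same change that separates compound 2 from compound 1, at a place described in the same words. Whether the change behaves alike on the methoxy core cannot be read from the three compounds measured, since it has been seen once only. The step from compound 3 to compound 4 is therefore expected to be a 1.6-fold lower number from compound 3 to compound 4 (0.19 log units; within the scatter), resting on the earlier step because a 1.6-fold lower number from compound 1 to compound 2 (0.22 log units; within the scatter) sits within the scatter. On that basis compound 4 is expected to give 19000 nM, with a range from 8000 nM to 45000 nM allowing for the untested core.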

Compound 4, half-maximal inhibitory concentration: 34300 nM
The estimate for compound 4 lay 1.8-fold (0.26 log units) below the measured number, within the range that was stated.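

In this assay, diethylamino in place of hydroxy on the core of compound 3 gives a 1.2-fold higher number from compound 3 to compound 4 (0.07 log units; within the scatter), and this agrees with the step seen for the same change on the core of compound 1: the same change on two cores in this assay, a 1.6-fold lower number (0.22 log units; within the scatter) from compound 1 to compound 2 and a 1.2-fold higher number (0.07 log units; within the scatter) from compound 3 to compound 4, 1.9-fold (0.28 log units) apart, within the scatter of two such steps

The core change, methyl in place of oxolan-3-yl on the oxygen, read now with the diethylamino group present, gives a 7.5-fold higher number from compound 2 to compound 4 (0.87 log units; beyond the scatter), and it too agrees with its earlier step: the same change on two cores in this assay, a 3.9-fold higher number (0.59 log units; beyond the scatter) from compound 1 to compound 3 and a 7.5-fold higher number (0.87 log units; beyond the scatter) from compound 2 to compound 4, 1.9-fold (0.28 log units) apart, within the scatter of two such steps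

Across these four compounds, then, each change carried from one core to the other with no difference that can be told from the scatter, but this rests on only two cores and one assay, and since both diethylamino steps lie within the scatter, they show no effect of that change in either direction on either core, and they give no reason why the oxolan-3-yl compounds show the lower numbers.

The compounds shown leave open whether other amines at the same place, such as dimethylamino or morpholine, would behave as diethylamino does. They also leave open how a longer chain or a chain ending in an amine on the oxygen, in place of methyl or oxolan-3-yl, would read.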